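Naphthalen-1-yl for 4-Methoxyphenyl: Inhibition Still Expected Absent

This account rests on a few compounds, and the source may have more. Where it says the series, first, only, none or still open, it means among the compounds named here.

Measured compounds, in an assay on CHO cells for displacement of a labelled ligand from adenosine receptor A3 (Homo sapiens), read by scintillation counting, with a stated time of 120 min, tested at 10 uM; on this read-out lower numbers stand for less inhibition and higher numbers for more inhibition at the one concentration tested (going by the name of the read-out):
- Compound 1 `Nc1scc(CN2CCN(c3ccc(Cl)cc3Cl)CC2)c1C(=O)c1ccc(Cl)cc1`: 0%
- Compound 2 `COc1ccc(N2CCN(Cc3csc(N)c3C(=O)c3ccc(Cl)cc3)CC2)cc1`: 0%
- Compound 3 `Nc1scc(CN2CCN(c3ccncc3)CC2)c1C(=O)c1ccc(Cl)cc1`: 2%

The three compounds share one core and differ only in the group carried on an amine nitrogen in a ring. In this assay none of them shows any appreciable inhibition. Compound 2 is level with compound 1 at the digits shown, and together these two give the lowest numbers of the three; the nearest neighbour of compound 2 is compound 1, with no change at the digits printed from compound 1 to compound 2 (within the scatter), and the furthest is compound 3, with a number 2 percentage points higher from compound 2 to compound 3 (within the scatter). The remaining step, a number 2 percentage points higher from compound 1 to compound 3 (within the scatter), is equally small.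

Compound 4 `Nc1scc(CN2CCN(c3cccc4ccccc34)CC2)c1C(=O)c1ccc(Cl)cc1` is the unmeasured member of the series. Its change from compound 2 is naphthalen-1-yl in place of 4-methoxyphenyl on an amine nitrogen in a ring. All three measured steps touch the same position, and each of them lies within the scatter, so there is no sign yet that any group on this nitrogen changes the read-out. Compound 4 is therefore expected to stay at the same level, with a number 2 percentage points higher from compound 2 to compound 4 (within the scatter) in this assay. The estimate for compound 4 is 2%, within a range of 0% to 12%.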

Compound 4, a percentage reported as inhibition, at one concentration (the size of the read-out at that concentration, not a potency): 0%
The estimate for compound 4 lay 2 percentage points above the measured number; measured number inside the range.
By their numbers in this assay, from the lowest: compounds 1, 2, 4 and 3 (each within the scatter of the next).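

In this assay, naphthalen-1-yl brings a second aromatic ring and removes the hydrogen-bond acceptor of 4-methoxyphenyl, yet the step is flat, with no change at the digits printed from compound 2 to compound 4 (within the scatter). The comparisons with the other two groups on this nitrogen are just as small, with a number 2 percentage points lower from compound 3 to compound 4 (within the scatter) and no change at the digits printed from compound 1 to compound 4 (within the scatter), so a group with two aromatic rings now joins the single-ring groups at the same level. Across these four compounds, no change on this nitrogen separates one from another, and no measurement is available to explain this flat result.

With every number this close to the bottom of the read-out at a single concentration, these compounds cannot show whether the group on this nitrogen would matter on a core that gave clear inhibition. Also open, on these data alone, is whether a group of a different kind there, such as benzyl, a short alkyl chain or a chain ending in a carboxylic acid, would lift the number, or whether replacing the 4-chlorophenyl group elsewhere on the shared core would do so.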